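Three Methoxy Groups Enter on the Saturated Ring Carbon

The source may hold more compounds than are shown below. What is called first, only, known or untested is meant among the compounds shown, and "the series" means these compounds.

Compound 1 `Cc1cc(O)c(C2=NN(c3ccc(S(N)(=O)=O)cc3)C(c3ccccc3)C2)cc1Cl`: 60.3%
Compound 2 `Cc1cc(O)c(C2=NN(c3ccc(S(N)(=O)=O)cc3)C(c3ccc(Cl)cc3)C2)cc1Cl`: 71.4%
Compound 3 `COc1cc(C)c(Cl)cc1C1=NN(c2ccc(S(N)(=O)=O)cc2)C(c2ccccc2)C1`: 59.5%

All three were tested in a functional assay on the whole organism (strain Wistar) for inhibition, with Rattus norvegicus as the target, read by paw edema, with stated times of 30 min and 5 h, at a dose of 20 mg/kg by the oral route; on this read-out higher numbers stand for more inhibition at the one dose given (going by the name of the read-out) and lower numbers for less inhibition. Compound 3 and compound 1 lie within the usual scatter of each other, as the step of a number 0.8 percentage points lower from compound 1 to compound 3 (within the scatter) shows, while compound 2 stands beyond the scatter above both.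

Compound 4 `COc1cc(C)c(Cl)cc1C1=NN(c2ccc(S(N)(=O)=O)cc2)C(c2ccc(OC)c(OC)c2OC)C1` differs from compound 3 in one place: 2,3,4-trimethoxyphenyl in place of phenyl on a saturated ring carbon. Among the measured compounds shown here, only one measured step touches that same phenyl, namely a number 11.1 percentage points higher from compound 1 to compound 2 (beyond the scatter), and it was modest. The methoxy step concerned another place and does not bear on this change. For the measured compounds named here, with no directly comparable step, a small upward move is expected, a number 3.5 percentage points higher from compound 3 to compound 4 (within the scatter). Compound 4 is therefore estimated at 63%, within 47% to 79%.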

Compound 4, a percentage reported as inhibition, in the whole organism at one dose (the size of the read-out at that dose, not a potency): 21.4%
Beside the measured number, compound 4's estimate is 41.6 percentage points above it; measured number below the stated range.
By their numbers in this assay, from the lowest: compound 4; then compounds 3 and 1 (each within the scatter of the next); then compound 2.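

At this position, on a saturated ring carbon, the larger group does not merely fail to help: in this assay 2,3,4-trimethoxyphenyl in place of phenyl gives a number 38.1 percentage points lower from compound 3 to compound 4 (beyond the scatter) and so takes away most of the inhibition. Among the compounds shown here, the only earlier change on this phenyl, a chloro in place of hydrogen, went the other way, with a number 11.1 percentage points higher from compound 1 to compound 2 (beyond the scatter) on a slightly different core. Nothing available explains the loss.

Whether a single methoxy group on this phenyl would already cause the drop stays open. So does the result of placing an amine or a carboxylic acid there.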